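Compound 2 to compound 4: a new aryl group on nitrogen

The compounds below may be only part of what the source reports. "The series", "measured", "known", "first", "only" and "open" are said of these compounds alone.

Values in a functional assay on ECa-109 cells for inhibition, with ECa-109 cell line (Homo sapiens) as the target, read by sulforhodamine B assay (on this read-out higher numbers stand for weaker inhibition and lower numbers for stronger inhibition), for the measured compounds
- compound 1 `CCc1ccc(NC2=CC(=O)c3c(nc4n3[C@H]3OC[C@@H](O)[C@H]3OC4)C2=O)cc1` gives > 4000 nM as a limit
- compound 2 `O=C1C=C(Nc2ccccc2F)C(=O)c2c1nc1n2[C@H]2OC[C@@H](O)[C@H]2OC1` gives 2760 nM as a number
- compound 3 `COc1ccccc1NC1=CC(=O)c2c(nc3n2[C@H]2OC[C@@H](O)[C@H]2OC3)C1=O` gives > 4000 nM as a limit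

Only compound 2 has a true number, and the others stand at the limit of > 4000 nM in this assay, at which 2 of the 3 values shown sit, so its place among them cannot be ranked exactly. Compound 4 `O=C1C=C(Nc2ccc(C(F)(F)F)cc2)C(=O)c2c1nc1n2[C@H]2OC[C@@H](O)[C@H]2OC1` is still unmeasured and differs from compound 2 as follows 4-(trifluoromethyl)phenyl in place of 2-fluorophenyl on an amine nitrogen with 4-(trifluoromethyl)phenyl in place of 2-fluorophenyl on an amine nitrogen.

Among the compounds with values here, the one measured step is a step that the two limits leave unreadable from compound 1 to compound 3 and it offers no size to carry over. Compound 1 has 4-ethylphenyl on that nitrogen and gives > 4000 nM as a limit, which is a thin hint towards weaker inhibition. Compound 3 gives > 4000 nM as a limit as well.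

The expected change is a 1.2-fold higher number from compound 2 to compound 4 (0.06 log units; within the scatter) in the direction of weaker inhibition, and it may stay within the scatter. A reading at the limit would not be surprising. For compound 4 the estimated value is 3200 nM with an expected range from 1300 nM to 7000 nM in this assay as the read-out.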

Compound 4, half-maximal inhibitory concentration: 5500 nM
Compound 4: the middle estimate sits 1.7-fold (0.24 log units) below what was measured, within the range that was stated.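

In this assay, this position on the amine nitrogen now has its first readable step: a 2.0-fold higher number from compound 2 to compound 4 (0.30 log units; within the scatter). Replacing 2-fluorophenyl with 4-(trifluoromethyl)phenyl therefore gives no difference that can be told from the scatter, even though the group and its substitution both change in this single step. The earlier step between the two compounds held at limits cannot be read, and much of the set still gives no exact number: the limit of > 4000 nM in this assay, at which 2 of the 4 values shown sit.

The two readable aryl groups both carry fluorine and differ in more than one feature, so this pair cannot separate the kind of fluorine-bearing group from where it sits on the ring. As far as these compounds go, it also remains open whether a plain phenyl, a pyridine ring, an aryl ring bearing a carboxylic acid or an amine, or a longer alkyl chain on this nitrogen would move the value in this assay beyond the scatter.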